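The source may report more compounds than this note shows. Statements on the series, on what has been measured and on what is new or still open speak of the compounds shown alone.

Compound 2 `CN1C(=O)CN(Cc2ccc(-c3cccc(CN4CCCCC4)n3)cc2)C1=O` gives 8.7 in a physicochemical assay for acid dissociation.
Compound 1 `CCN1C(=O)CN(Cc2ccc(-c3ccc(F)c(CN4CCCCC4)n3)cc2)C1=O` gives 8.5 in this assay.
Compound 3 `O=C1CN(Cc2ccc(-c3ccc(F)c(CN4CCCCC4)n3)cc2)C(=O)N1CC1CC1` gives 8.5 in this assay.

All three numbers sit close together: compound 2 gives the number at the top end, yet the values of compound 1 and compound 3 both lie within the scatter of it. Compound 4 `O=C1CN(Cc2ccc(-c3cccc(CN4CCCCC4)n3)cc2)C(=O)N1C1CC1` has not been measured in this assay. It differs from compound 2 in one place: cyclopropyl in place of methyl on an amide-type nitrogen in a ring. Among the measured compounds shown here, the only measured step that bears on this is the change from compound 1 to compound 3, where a cyclopropyl also replaced a methyl near the same amide-type nitrogen, and it gave no change at the digits printed from compound 1 to compound 3 (within the scatter). The step here is not the same, as the cyclopropyl sits directly on the ring nitrogen, so the comparison is a guide rather than a match. On that basis no step beyond the scatter is expected, no change at the digits printed from compound 2 to compound 4 (within the scatter). For compound 4 the expected value in this assay is 8.7, estimated to lie between 8.4 and 9.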

Compound 4, acid dissociation constant: 9
For compound 4 the middle estimate is 0.30 log units below the measured one; low and high end bracket the measured number.
By their numbers in this assay, from the lowest: compounds 1, 3, 2 and 4 (each within the scatter of the next, the first and the last beyond it).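

Cyclopropyl in place of methyl on an amide-type nitrogen in a ring gives a number 0.30 log units higher from compound 2 to compound 4 (within the scatter) in this assay and so no shift that stands clear of the usual scatter. The earlier step placed cyclopropyl on a saturated chain carbon, whereas this result shows that the same three-membered ring bound directly to the ring nitrogen also stays within the scatter. As far as these compounds go, whether an amine, a carboxylic acid or a longer chain on this nitrogen would do the same remains open, and no supporting measurement bears on this result.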